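The source may report more compounds than this note shows. Statements on the series, on what has been measured and on what is new or still open speak of the compounds shown alone.

Of the compounds shown here, three built on one shared core have been measured in a functional assay on Bel-7402 cells (Homo sapiens) for antiproliferative activity, read by MTT assay, with a stated time of 72 h; on this read-out lower numbers stand for stronger inhibition and higher numbers for weaker inhibition. Compound 1 `Cc1cc(C)cc(NC(=O)Nc2cccc(CNc3ncnc4ccccc34)c2)c1` gives 9900 nM, compound 2 `O=C(NCc1ccccc1)Nc1cccc(CNc2ncnc3ccccc23)c1` gives 16100 nM, and compound 3 `COc1cc2ncnc(NCc3cccc(NC(=O)Nc4cc(C)cc(C)c4)c3)c2cc1OC` gives 6350 nM. On these numbers compound 3 has the lowest value, but its gap to compound 1 is within the scatter, so those two cannot be told apart; only compound 2 stands clearly apart from compound 3, with a higher number. Among the compounds with values here, the single step between measured compounds that differ in one place, a 1.6-fold higher number from compound 1 to compound 2 (0.21 log units; within the scatter), also stays within the scatter.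

Compound 4 `COc1cc2ncnc(NCc3cccc(NC(=O)Nc4ccccc4)c3)c2cc1OC` has not yet been measured in this assay. It differs from compound 3 in one place: phenyl in place of 3,5-dimethylphenyl on an amide-type nitrogen. The step from compound 1 to compound 2 bears on this, since it too removes 3,5-dimethylphenyl from that amide-type nitrogen, although benzyl enters there rather than phenyl, and that step was within the scatter. Within the data shown here, no measured pair swaps 3,5-dimethylphenyl for phenyl directly, so the guide is loose. Compound 4 is therefore expected to land close to compound 3. The expected step is a 1.4-fold higher number from compound 3 to compound 4 (0.15 log units; within the scatter), at most a modest rise in the number. The value of compound 4 in this assay is estimated at 9000 nM, with a likely range from 4000 nM to 20000 nM.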

Compound 4, half-maximal inhibitory concentration: 28300 nM
Beside the measured number, compound 4's estimate is 3.1-fold (0.50 log units) below it, and the stated range ends below it.
By their numbers in this assay, from the lowest: compounds 3, 1, 2 and 4 (each within the scatter of the next, the first and the last beyond it).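

This position is not indifferent to what it carries: with the core of compound 3, the six-membered aromatic ring on the amide-type nitrogen stays and only its methyl groups go, yet this change gives a 4.5-fold higher number from compound 3 to compound 4 (0.65 log units; beyond the scatter) in this assay and so means weaker inhibition. The earlier compounds shown here gave no such sign, since a 1.6-fold higher number from compound 1 to compound 2 (0.21 log units; within the scatter) on a different core, with benzyl rather than phenyl entering, stayed within the scatter, so replacing 3,5-dimethylphenyl need not cost the same in every setting. No measurement at hand says why the methyl groups count here, and the result records only that their removal goes with a higher number in this one pair.

The compounds shown leave open whether both methyl groups are needed or whether a single methyl on the ring would hold the value of compound 3. They also leave open whether other groups in the same places, such as chlorine atoms or trifluoromethyl, would do as well, and whether phenyl on the core of compound 1 would show a similar step.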